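Ethyl to tert-butyl on a shared core: an expectation

The compounds below may be only part of what the source reports. "The series", "measured", "known", "first", "only" and "open" are said of these compounds alone.

The measured compounds and their values:
compound 1, `CCc1nc2c(C(=O)NCC3CCN(CC(O)CN4CCN(S(C)(=O)=O)CC4)CC3)cccc2[nH]1`: 1 nM
compound 2, `CC(=O)N(C)CC(O)CN1CCC(CNC(=O)c2cccc3[nH]c(C(C)C)nc23)CC1`: 1.59 nM
compound 3, `CC(=O)N1CCC(CN2CCC(CNC(=O)c3cccc4[nH]c(C(C)C)nc34)CC2)CC1`: 1.59 nM

In a functional assay for agonist activity at 5-hydroxytryptamine receptor 4 (Homo sapiens), read by cAMP accumulation (a lower number here means that less compound is needed, a higher number that more compound is needed for the effect), compound 1 gives 1 nM, the lowest of the three numbers, although its gaps to compound 2 and to compound 3 both lie within the scatter, so no order among the three can be claimed. Among the compounds with values here, the only measured step, no change at the digits printed from compound 2 to compound 3 (within the scatter), concerns a distant part of the molecule and does not touch the group on the five-membered ring.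

Compound 4, `CC(C)(C)c1nc2c(C(=O)NCC3CCN(CC(O)CN4CCN(S(C)(=O)=O)CC4)CC3)cccc2[nH]1`, differs from compound 1 in one place: tert-butyl in place of ethyl on an aromatic carbon. Within the data shown here, no measured step bears directly on this change. Compound 2 and compound 3 carry an isopropyl group at the same place and give values close to that of compound 1, but since they also differ elsewhere, only their two values can be read, not a step. Without any guide, the expected step from compound 1 to compound 4 is a 1.5-fold higher number from compound 1 to compound 4 (0.18 log units; within the scatter), that is, none beyond the scatter. Compound 4 is therefore estimated at 1.5 nM, with a range from 0.5 nM to 5 nM.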

Compound 4, half-maximal effective concentration: 3.16 nM
Estimate against measurement, compound 4: 2.1-fold (0.32 log units) below; the range from low to high includes it.
By their numbers in this assay, from the lowest: compounds 1, 2, 3 and 4 (each within the scatter of the next, the first and the last beyond it).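

In this assay, the exchange of ethyl for tert-butyl on the aromatic carbon between two ring nitrogen atoms gives a 3.2-fold higher number from compound 1 to compound 4 (0.50 log units; beyond the scatter), the first step shown at this position and one that lies beyond the scatter. Within the data shown here, the earlier compounds could show only that values stayed close when a distant part of the molecule changed, whereas this step shows that the number also responds to the group at this place on the five-membered aromatic ring, though modestly, with four carbon atoms entering where two leave and compound 4 still at 3.16 nM. Nothing at hand explains why the number rises with this change.

The compounds shown do not settle whether the rise follows the size of an alkyl group, since isopropyl appears only in compound 2 and compound 3, which also differ from compound 1 elsewhere, so no step to isopropyl can be read. They also leave open how this place would respond to a cyclopropyl ring, a methoxymethyl group or an amine in place of ethyl.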